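A few compounds are considered here, and "the series" means these few. Any claim that something is new, unique, unknown or untested is made for them only; others in the source may bear on it.

Measured compounds in a functional assay on HEK293 cells for antagonist activity at corticotropin-releasing factor receptor 1 (Homo sapiens), read by fluorescence and cAMP accumulation, with a stated time of 30 min; a lower number here means a stronger inhibitor, a higher number a weaker inhibitor:
compound 1 `COCc1cc(OC)c(-c2cccc3c(N(CC4CCOCC4)CC4CC4)c(C#N)nn23)c(OC)c1`: 52 nM
compound 2 `CCc1nn2c(-c3c(OC)cc(C)cc3OC)cccc2c1N(CC1CCOCC1)CC1CC1`: 20 nM

Compound 1 gives the higher of the two numbers in this assay; the gap to compound 2 lies beyond the scatter. Compound 3 `COCc1cc(OC)c(-c2cccc3c(N(CC4CCOCC4)CC4CC4)c(SC)nn23)c(OC)c1` differs from compound 1 by methylsulfanyl in place of cyano on an aromatic carbon. Among the measured compounds shown here, no measured pair shows this change, so the expected step from compound 1 to compound 3 is small and set at a 1.5-fold lower number from compound 1 to compound 3 (0.17 log units; within the scatter), within the scatter or a little downward. On that basis compound 3 is estimated at 35 nM in this assay, with a range from 10 nM to 120 nM.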

Compound 3, half-maximal inhibitory concentration: 30 nM
Beside the measured number, compound 3's estimate is 1.2-fold (0.07 log units) above it; the measured number falls inside the stated range.
By their numbers in this assay, from the lowest: compounds 2, 3 and 1 (each within the scatter of the next, the first and the last beyond it).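

Methylsulfanyl in place of cyano on the aromatic carbon next to the ring nitrogen gives a 1.7-fold lower number from compound 1 to compound 3 (0.24 log units; within the scatter) in this assay. On the core of compound 1, this position therefore carries either group without a difference beyond the scatter, so the two groups are not told apart here. Nothing on hand bears on why they read alike.

Open, on these data alone, is whether an amine, a carboxylic acid or a longer chain such as butylsulfanyl on this carbon would separate from these two groups. Also open, as far as these compounds go, is whether the same swap reads alike with other groups elsewhere on the core.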